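The source may report more compounds than this note shows. Statements on the series, on what has been measured and on what is new or still open speak of the compounds shown alone.

Measured compounds in a functional assay on MCF7 cells (Homo sapiens) for cytotoxicity, with a stated time of 72 h; a higher number here means a weaker inhibitor, a lower number a stronger inhibitor:

Compound 1, `C[C@H](NC(=O)c1cc(Cl)ccc1O)C(=O)Nc1ccc(C(F)(F)F)cc1`, gives > 12500 nM in this assay, which is a limit of the assay and not a number.
Compound 2, `CC(C)[C@H](NC(=O)c1cc(Cl)ccc1O)C(=O)Nc1ccc(C(F)(F)F)cc1`, gives 7300 nM in this assay.
Compound 3, `C[C@H](NC(=O)c1ccc(Cl)cc1O)C(=O)Nc1ccc(Cl)cc1`, gives > 10000 nM in this assay, again a limit of the assay and not a number.

Compound 1 and compound 2 share a core and differ only by isopropyl in place of methyl on a saturated chain carbon bound to an amide-type nitrogen and a carbonyl carbon. That change gave an at least 1.7-fold lower number from compound 1 to compound 2 (0.23 log units; that floor lies within the scatter) in this assay. Compound 3 carries a different core; the difference between the two cores is not broken down here. Compound 4, `CC(C)[C@H](NC(=O)c1ccc(Cl)cc1O)C(=O)Nc1ccc(Cl)cc1`, is not yet measured in this assay. It stands to compound 3 exactly as compound 2 stands to compound 1, the change being (isopropyl in place of methyl on a saturated chain carbon bound to an amide-type nitrogen and a carbonyl carbon), the same change at the same place.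

For the measured compounds named here, since compound 3 sits at the limit of > 10000 nM in this assay, at which 1 of the 3 values shown sits, and the one earlier instance of this change moved compound 1 off the limit of > 12500 nM in this assay, at which 1 of the 3 values shown sits, only to a value whose step floor lies within the scatter, compound 4 is expected to show a step of an at least 1.1-fold lower number from compound 3 to compound 4 (0.04 log units; that floor lies within the scatter) in this assay, with real uncertainty about whether a number will be reported at all. Compound 4 is therefore estimated at 9000 nM in this assay, with a plausible span from 3000 nM to 30000 nM.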

Compound 4, half-maximal inhibitory concentration: > 10000 nM
Compound 4 ended at the assay's limit; the forecaster's own chance of this, stated with the estimate: 45%; middle value at least 1.1-fold (0.04 log units) away from the limit.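

In this assay compound 4 gives > 10000 nM, which is a limit of the assay and not a number. Compound 3 also stands at a limit, so no step can be read between compound 3 and compound 4. The compounds shown leave open whether isopropyl in place of methyl changes the number at all on the core of compound 3.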